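A few compounds are considered here, and "the series" means these few. Any claim that something is new, unique, unknown or untested is made for them only; others in the source may bear on it.

Measured compounds:
Compound 1, `Oc1ccc(-c2cc(-c3ccsc3)nc(-c3cccc(Cl)c3)c2)cc1`, in a functional assay on HCT-15 cells (Homo sapiens) for cytotoxicity, read by CCK-8 assay and cell counting, with a stated time of 2 days (a higher number here means a weaker inhibitor, a lower number a stronger inhibitor), compound 1 gives 5760 nM.
Compound 2, `Oc1cccc(-c2cc(-c3cccc(Cl)c3)nc(-c3ccccn3)c2)c1`, in this assay compound 2 gives "not determined" (no result reported).
Compound 3, `Oc1cccc(-c2cc(-c3cccc(Cl)c3)nc(-c3cccs3)c2)c1`, in this assay compound 3 gives 2610 nM.

Compound 3 has the lowest of the two numbers given, and so is the stronger inhibitor of the pair with a number. Its nearest neighbour is compound 1, whose higher number lies beyond the usual scatter of repeated measurements, so the difference between compound 1 and compound 3 is real and not noise. Compound 2 stands apart, since no number exists for it.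

The next compound, compound 4, `Oc1cccc(-c2cc(-c3ccsc3)nc(-c3cccc(Cl)c3)c2)c1`, is built from the same atoms as compound 3, joined differently. The change is thiophen-3-yl in place of thiophen-2-yl on an aromatic carbon. Compound 1 already carries a thiophen-3-yl group, together with a different hydroxyphenyl group, and gives 5760 nM, while compound 3 with the thiophen-2-yl group gives 2610 nM. On this slim basis, a small shift toward a weaker inhibitor is expected, with the step from compound 3 to compound 4 estimated as a 1.3-fold higher number from compound 3 to compound 4 (0.13 log units; within the scatter), probably within the scatter. Compound 4 is therefore expected to give about 3500 nM, in a range from 1500 nM to 8000 nM.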

Compound 4, half-maximal inhibitory concentration: 2510 nM
Estimate against measurement, compound 4: 1.4-fold (0.14 log units) above, within the range that was stated.
By their numbers in this assay, from the lowest: compounds 4 and 3 (each within the scatter of the next); then compound 1.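

In this assay, placing thiophen-3-yl instead of thiophen-2-yl on the aromatic carbon next to the ring nitrogen gives a 1.0-fold lower number from compound 3 to compound 4 (0.02 log units; within the scatter) and so leaves the number unchanged in practice, which means that at this position the point of attachment of the thiophene makes no measurable difference between these two compounds. Among these compounds, compound 4 also allows the first comparison in which only the hydroxyphenyl group differs: 3-hydroxyphenyl in place of 4-hydroxyphenyl gives a 2.3-fold lower number from compound 1 to compound 4 (0.36 log units; beyond the scatter) and is a modest step, but unlike the thiophene change it lies beyond the usual scatter, so of the two changes this is the one that moves the number. Nothing available here explains either result.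

On these data alone, both thiophene groups are close relatives, so it remains open whether the position next to the ring nitrogen would tolerate something of a quite different kind, such as an amine, a carboxylic acid or a longer alkyl chain. As far as these compounds go, it is equally open whether the hydroxyl group itself is needed on the phenyl ring, which a methoxy group or an amine in its place could test.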